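This account rests on a few compounds, and the source may have more. Where it says the series, first, only, none or still open, it means among the compounds named here.

Measured compounds in a functional assay on MCF7 cells (Homo sapiens) for cytotoxicity, read by MTT assay, with a stated time of 72 h; on this read-out higher numbers stand for weaker inhibition and lower numbers for stronger inhibition:
compound 1 `Cc1ccc(-c2ccnc(C(=O)Nc3ccc(Oc4ccnc5[nH]ccc45)cc3)n2)cc1`: 6410 nM
compound 2 `O=C(Nc1ccc(Oc2ccnc3[nH]ccc23)cc1)c1nccc(-c2ccc(Cl)cc2)n1`: "not active" (no number reported)
compound 3 `Cc1ccc(-c2ccnc(C(=O)Nc3ccc(Oc4ccnc5[nH]ccc45)c(F)c3)n2)cc1`: 7170 nM

In this assay compound 3 gives 7170 nM, the higher of the two numbers reported; its nearest neighbour is compound 1, which gives 6410 nM, and the step of a 1.1-fold higher number from compound 1 to compound 3 (0.05 log units; within the scatter) lies within the scatter. Compound 2 is reported only as "not active" (no number reported). Compound 4 `O=C(Nc1ccc(Oc2ccnc3[nH]ccc23)c(F)c1)c1nccc(-c2ccc([N+](=O)[O-])cc2)n1` is obtained by the change (nitro in place of methyl on an aromatic carbon). Among the measured compounds shown here, no measured step covers this change; the only measured step, from compound 1 to compound 3, concerns the fluoro substituent that compound 3 and compound 4 share, and it was flat. Compound 2 shows that altering the same aryl substituent can remove measurable activity. Compound 4 is therefore expected to be somewhat weaker, an estimated step of a 2.1-fold higher number from compound 3 to compound 4 (0.32 log units; beyond the scatter). The estimate for compound 4 is 15000 nM, with a range from 4000 nM to 60000 nM.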

Compound 4, half-maximal inhibitory concentration: "not active" (no number reported)
Nothing numeric was reported for compound 4, and the estimate cannot be compared.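

Among the compounds shown here, compound 4, like compound 2, is reported in this assay as "not active" without a number, so no step from compound 3 to compound 4 can be read. Nothing shown here accounts for this result. The compounds shown leave open how far 4-methylphenyl to 4-nitrophenyl shifts the number.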